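Swapping the aryl ketone in a weakly cytotoxic series

The source may hold more compounds than are shown below. What is called first, only, known or untested is meant among the compounds shown, and "the series" means these compounds.

Measured compounds:
Compound 1, `COc1ccc(C(=O)C2Sc3nnc(-c4cc(OC)c(OC)c(OC)c4)n3NC2c2cccs2)cc1`, gives 49500 nM.
Compound 3, `COc1cc(C(=O)C2Sc3nnc(-c4cc(OC)c(OC)c(OC)c4)n3NC2c2cccs2)cc(OC)c1OC`, gives 71000 nM.
For compound 2, `COc1cc(-c2nnc3n2NC(c2ccco2)C(C(=O)c2cccs2)S3)cc(OC)c1OC`, the assay reports only a limit, > 100000 nM.

All three were tested in a functional assay on MCF7 cells (Homo sapiens) for cytotoxicity, read by MTT assay, with a stated time of 48 h; a lower number here means a stronger inhibitor, a higher number a weaker inhibitor. Compound 2 therefore stands at the weak end of what the assay can report, as the limit of > 100000 nM in this assay, at which 1 of the 3 values shown sits, shows, while compound 1 and compound 3 give numbers that are themselves high.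

Compound 4, `COc1cc(-c2nnc3n2NC(c2ccco2)C(C(=O)c2ccc(F)cc2)S3)cc(OC)c1OC`, has not yet been measured. It differs from compound 2 in one place: 4-fluorophenyl in place of thiophen-2-yl on a carbonyl carbon. Among the compounds with values here, one measured step bears on this kind of change, since it also exchanges the aryl group on the carbonyl carbon: a 1.4-fold higher number from compound 1 to compound 3 (0.16 log units; within the scatter). That step stayed within the scatter, so no movement beyond the scatter is expected from the change from compound 2 to compound 4. Compound 4 is therefore expected to sit near the same limit, with an estimated value of 120000 nM, most likely between 50000 nM and 300000 nM, which means an expected step that the limit leaves unreadable from compound 2 to compound 4.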

Compound 4, half-maximal inhibitory concentration: > 100000 nM
Compound 4: no number, only a limit; the forecaster's own chance of this, stated with the estimate: 60%; the middle value lies beyond the limit too.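

Compound 2 and compound 4 each give only a limit in this assay and no number, so the step between them, 4-fluorophenyl in place of thiophen-2-yl on a carbonyl carbon, cannot be read. The compounds shown leave open how far past that limit either compound lies.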